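The compounds below may be only part of what the source reports. "The series", "measured", "known", "first", "only" and "open" are said of these compounds alone.

Measured compounds:
compound 1, `O=C(N/N=C/c1ccccn1)c1cccc(Br)c1`, 13500 nM in an ADME assay on cells (Homo sapiens) for antiproliferative activity, read by MTT assay; a lower number here means a stronger inhibitor, a higher number a weaker inhibitor
compound 2, `Nc1ccc(C(=O)NN=C(c2ccccn2)c2ccccn2)cc1`, 7640 nM in this assay

In this assay compound 2 gives 7640 nM and compound 1 gives 13500 nM; the two numbers lie within the scatter of one another, so neither compound can be ranked ahead of the other. Compound 3, `O=C(NN=C(c1ccccn1)c1ccccn1)c1ccc(Br)cc1`, has not yet been measured; it differs from compound 2 by bromo in place of amino on an aromatic carbon. Within the data shown here, with no comparable pair measured, no step beyond the scatter is expected in this assay, and compound 3 is estimated at 6000 nM, within 1500 nM to 20000 nM, meaning an expected step of a 1.3-fold lower number from compound 2 to compound 3 (0.10 log units; within the scatter).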

Compound 3, half-maximal inhibitory concentration: 300 nM
The estimate for compound 3 lay 20-fold (1.30 log units) above the measured number; measured number outside the range, below it.
By their numbers in this assay, from the lowest: compound 3; then compounds 2 and 1 (each within the scatter of the next).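

Among these compounds, replacing amino with bromo on this aromatic carbon gives a 25-fold lower number from compound 2 to compound 3 (1.41 log units; beyond the scatter) in this assay, the only step beyond the scatter that can be read here. The position para to a large group therefore responds strongly to the group it carries, at least for this single change on the shared core. Nothing available explains the size of this step.

From the compounds shown here alone, it remains open whether the step reflects the arrival of bromo or the departure of amino. Going by these compounds, how chloro, methoxy or a carboxylic acid would read at this position also remains open.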